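Swapping a Hydroxy for a Dimethylamino Group

The source may hold more compounds than are shown below. What is called first, only, known or untested is meant among the compounds shown, and "the series" means these compounds.

Of the compounds shown here, two sharing one core have so far been tested in a functional assay on the whole organism (strain Wistar) for inhibition, with Rattus norvegicus as the target, read by paw edema, with a stated time of 4 h, at a dose of 10 mg/kg by the intraperitoneal route; on this read-out lower numbers stand for less inhibition and higher numbers for more inhibition at the one dose given (going by the name of the read-out). Compound 1 `O=C(N/N=C/c1ccc(O)cc1)c1cccnc1Nc1cccc(C(F)(F)F)c1` gives 61.6%, the higher of the two numbers. Compound 2 `COc1cc(/C=N/NC(=O)c2cccnc2Nc2cccc(C(F)(F)F)c2)cc(OC)c1OC` gives 28.6%, and the gap between these two values lies beyond the usual scatter of repeated measurements of this kind. Compound 3 `CN(C)c1ccc(/C=N/NC(=O)c2cccnc2Nc2cccc(C(F)(F)F)c2)cc1` has not been measured yet. It differs from compound 1 in one place: dimethylamino in place of hydroxy on an aromatic carbon. Going by the values given here, no measured pair shows this particular change, so the numbers at hand give no direct guide to how large a step it brings; the lower number of compound 2 is the only other point of reference. The expected step of a number 11.6 percentage points lower from compound 1 to compound 3 (beyond the scatter) is a modest drop, near the edge of the scatter. Compound 3 is expected to give about 50%, with a likely range from 32% to 68%.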

Compound 3, a percentage reported as inhibition, in the whole organism at one dose (the size of the read-out at that dose, not a potency): 28.2%
Beside the measured number, compound 3's estimate is 21.8 percentage points above it, outside the stated range (below it).
By their numbers in this assay, from the lowest: compounds 3 and 2 (each within the scatter of the next); then compound 1.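

In this assay the swap from 4-hydroxyphenyl to 4-(dimethylamino)phenyl gives a number 33.4 percentage points lower from compound 1 to compound 3 (beyond the scatter) and so provides the first direct measure of a single change at this place on the ring, showing that the read-out responds to what sits there. The change removes the hydrogen-bond donor counted for hydroxy and adds heavy atoms, but both differences arrive together, so this one step cannot separate them. Nothing available here bears on why the number falls.

On these data alone, whether a primary amine or a methoxy group at the same place would give a number closer to that of compound 1 or compound 3 remains open. Also open, as far as these compounds go, is whether the same swap would bring a step of similar size on a different core.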